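From 4-Bromophenyl to Phenyl: An Expected Small Step

The source may report more compounds than this note shows. Statements on the series, on what has been measured and on what is new or still open speak of the compounds shown alone.

Three compounds have so far been measured in a functional assay on MCF7 cells (Homo sapiens) for antiproliferative activity, read by sulforhodamine B assay, with a stated time of 72 h, tested at 10 uM; on this read-out higher numbers stand for a weaker effect at the one concentration tested and lower numbers for a stronger effect:

compound 1, `COC(=O)C1=C(N)Oc2c(OC)cc(Br)cc2C1CC(=O)c1ccc(Cl)cc1`, giving 80.3%
compound 2, `COC(=O)C1=C(N)Oc2ccc(Br)cc2C1CC(=O)c1ccc(Br)cc1`, giving 72.5%
compound 3, `COC(=O)C1=C(N)Oc2c(OC)cccc2C1CC(=O)c1ccc(Cl)cc1`, giving 89.8%

Compound 2 holds the lowest of the three numbers. Its nearest neighbour is compound 1, a number higher but within the scatter, while compound 3 stands further away, beyond the scatter. Compounds 1 and 3 differ in a single place, (hydrogen in place of bromo on an aromatic carbon), and the step between them, a number 9.5 percentage points higher from compound 1 to compound 3 (within the scatter), lies within the scatter. The difference between the cores of compound 1 and compound 2 is not broken down here.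

Compound 4, `COC(=O)C1=C(N)Oc2ccc(Br)cc2C1CC(=O)c1ccccc1`, has not yet been measured in this assay. It differs from compound 2 by hydrogen in place of bromo on an aromatic carbon. This is the same kind of change as that from compound 1 to compound 3, but the surroundings are not the same: in the earlier pair the bromo sits on a ring that is part of a fused or bridged system of two rings, meta to a fused ring, meta to a methoxy group and para to a fused ring, whereas here it sits on a six-membered aromatic ring of carbon only, para to a large group. Within the data shown here, because the earlier step of a number 9.5 percentage points higher from compound 1 to compound 3 (within the scatter) stayed within the scatter, a similarly small step is expected here, a number 5.5 percentage points higher from compound 2 to compound 4 (within the scatter), though only one prior example of this kind of change is available and it sits in different surroundings. Compound 4 is therefore estimated to give 78%, with the likely range running from 62% to 94%.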

Compound 4, a percentage reported as activity, at one concentration (the size of the read-out at that concentration, not a potency): 107%
Compound 4: the middle estimate sits 29 percentage points below what was measured; the whole stated range lies below it.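

In this assay, putting hydrogen in place of bromo, which turns the 4-bromophenyl group into phenyl, gave a large step, a number 34.5 percentage points higher from compound 2 to compound 4 (beyond the scatter), and on this read-out that means a much weaker effect at the one concentration tested. The size of this change therefore did not carry from one core to the other in this series, as the two pairs show when set side by side: the same change on two cores in this assay, a number 9.5 percentage points higher (within the scatter) from compound 1 to compound 3 and a number 34.5 percentage points higher (beyond the scatter) from compound 2 to compound 4, 25 percentage points apart, beyond the scatter of two such steps What the pairs do not show is whether the gap belongs to the core itself or to the place of the bromo, since the bromo leaves a different ring in each pair, and in compound 2 it sits on a six-membered aromatic ring of carbon only, para to a large group; with a single pair of each kind, neither a general rule for this change nor an explanation of the gap can be drawn.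

The compounds shown leave open whether a fluoro, a methyl or an amine in the place of this bromo would keep the effect seen with compound 2 or lose it as compound 4 does. They also leave open whether the chloro on the same kind of ring in compound 1 and compound 3 could be exchanged for hydrogen with a similarly large step.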